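The source may report more compounds than this note shows. Statements on the series, on what has been measured and on what is new or still open speak of the compounds shown alone.

Within the data shown here, in a toxicity assay on cells (Macrophage, Mus musculus, strain BALB/c) for cytotoxicity, read by MTT assay (on this read-out higher numbers stand for weaker inhibition and lower numbers for stronger inhibition), the series so far holds two numbers. Compound 1 (`C=CCOc1cc(OC)c(C(=O)/C=C/c2cccc(OC)c2)c(OCC=C)c1`) gives 13100 nM and compound 2 (`C=CCOc1cc(OC)c(C(=O)/C=C/c2ccccc2Br)c(OCC=C)c1`) gives 5400 nM as the lower of the pair. Compound 3 (`C=CCOc1cc(OC)c(C(=O)/C=C/c2ccccn2)c(OCC=C)c1`) is still unmeasured. Its difference from compound 2 is pyridin-2-yl in place of 2-bromophenyl on a double-bonded chain carbon bound to a double-bonded chain carbon and lies on a double-bonded chain carbon bound to a double-bonded chain carbon. Among the measured compounds shown here, one measured step bears on this place: a 2.4-fold lower number from compound 1 to compound 2 (0.38 log units; beyond the scatter) is modest and beyond the scatter. That step involves no pyridin-2-yl, so the support is thin. In this assay a step of similar modest size is expected, towards a higher number, and this direction is tentative. The estimate amounts to a 2.0-fold higher number from compound 2 to compound 3 (0.31 log units; beyond the scatter) as an expected step. For compound 3 the estimated value is 11000 nM with an expected range of 4500 nM to 28000 nM on this read-out.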

Compound 3, half-maximal inhibitory concentration: 12500 nM
Estimate against measurement, compound 3: 1.1-fold (0.06 log units) below; low and high end bracket the measured number.
By their numbers in this assay, from the lowest: compound 2; then compounds 3 and 1 (each within the scatter of the next).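

Working from this assay, pyridin-2-yl in place of 2-bromophenyl on a double-bonded chain carbon bound to a double-bonded chain carbon gives a 2.3-fold higher number from compound 2 to compound 3 (0.36 log units; beyond the scatter), so the lowest number in the series now stands apart from two other groups at this place rather than one. Pyridin-2-yl and 3-methoxyphenyl are not told apart, with a 1.0-fold lower number from compound 1 to compound 3 (0.02 log units; within the scatter), although the two groups differ in their ring atoms; among the three compounds, only the 2-bromophenyl group separates from the others. Nothing measured here accounts for this separation.

Going by these compounds, whether the separation belongs to bromine itself or to the aromatic ring that carries it remains open. A 2-chlorophenyl or 2-methylphenyl group at this place could show whether such groups read with compound 2 or with compound 3.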